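Four Compounds, One Limit, and a Thiazole Swap

The compounds below may be only part of what the source reports. "The series", "measured", "known", "first", "only" and "open" are said of these compounds alone.

Values in a functional assay on HUVEC cells (Homo sapiens) (a higher number here means that more compound is needed for the effect, a lower number that less compound is needed), are all limits of the assay:
- Compound 1 (`COC1=C(C)C(=O)/C(=C(O)/C=C/c2ccc(C)cc2)C(=O)C1(C)C`) gives < 4 ug/mL as a limit.
- Compound 2 (`COC1=C(C)C(=O)/C(=C(O)/C=C/c2c(C)cc(C)cc2C)C(=O)C1(C)C`) gives < 4 ug/mL as a limit.
- Compound 3 (`COC1=C(C)C(=O)/C(=C(O)/C=C/c2cccc3ccccc23)C(=O)C1(C)C`) gives < 4 ug/mL as a limit.

Compound 1 has no exact number and stands at the limit of < 4 ug/mL in this assay, at which 3 of the 3 values shown sit, as its only position. Compound 4 (`COC1=C(C)C(=O)/C(=C(O)/C=C/c2nccs2)C(=O)C1(C)C`) keeps the core of compound 1 and changes one group, with 1,3-thiazol-2-yl in place of 4-methylphenyl on a double-bonded chain carbon bound to a double-bonded chain carbon. No measured pair among these compounds differs in one place, so no single change can be sized directly in this assay. The groups at this place differ across compound 1, compound 2 and compound 3, yet the three share one limit. On that basis no step beyond the scatter is expected, in either direction. The estimated step that the limit leaves unreadable from compound 1 to compound 4 is expected to stay within the usual scatter, and the assay may again report only a limit. Compound 4 is expected at 3 ug/mL in this assay, with 0.8 ug/mL to 10 ug/mL as the estimated range.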

Compound 4, concentration for half-maximal effect: < 4 ug/mL
Compound 4: only a limit was reported (the forecaster's own chance of this, stated with the estimate: 60%); the middle value lies beyond the limit too.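

No step can be read from compound 1 to compound 4, because both compounds give only a limit in this assay and no exact number: the limit of < 4 ug/mL in this assay, at which 4 of the 4 values shown sit.

The compounds shown leave open how far each lies beyond that limit, and whether 1,3-thiazol-2-yl in place of 4-methylphenyl changes anything.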